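Phenyl for methyl on the ring amine nitrogen of compound 1

This account rests on a few compounds, and the source may have more. Where it says the series, first, only, none or still open, it means among the compounds named here.

Measured so far in a functional assay on cells (Melanoma cell, Homo sapiens) for inhibition, with a stated time of 48 h; on this read-out lower numbers stand for stronger inhibition of growth and higher numbers for weaker inhibition of growth:
compound 1 `CN1CCN(C(=O)c2c(NC(=O)NS(=O)(=O)c3ccccc3)sc3c2CCCCC3)CC1` gives 61200 nM
compound 2 `O=C(Nc1sc2c(c1C(=O)NNc1ccc(Cl)cc1)CCCCC2)NS(=O)(=O)c1ccccc1` gives 4200 nM
compound 3 `CCCNC(=O)c1c(NC(=O)NS(=O)(=O)c2ccccc2)sc2c1CCCCC2` gives 65300 nM

Compound 1 stands second highest of the three numbers. Its nearest neighbour is compound 3, with a 1.1-fold higher number from compound 1 to compound 3 (0.03 log units; within the scatter); the furthest is compound 2, with a 15-fold lower number from compound 1 to compound 2 (1.16 log units; beyond the scatter). Compound 3 against compound 2 reads a 16-fold higher number from compound 2 to compound 3 (1.19 log units; beyond the scatter).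

Compound 4 `O=C(Nc1sc2c(c1C(=O)N1CCN(c3ccccc3)CC1)CCCCC2)NS(=O)(=O)c1ccccc1` differs from compound 1 in one place: phenyl in place of methyl on an amine nitrogen in a ring. Cut one bond further out, the change reads 4-methylpiperazin-1-yl to 4-phenylpiperazin-1-yl, so the amide carbonyl and the shared core are untouched.

Going by the values given here, no measured step changes a group on the amine nitrogen in the ring. The two large steps, from compound 1 to compound 2 and from compound 2 to compound 3, both replace the whole group on the carbonyl carbon, which is a different place and a different kind of change. The step from compound 1 to compound 3, which also acts at the carbonyl carbon, stays within the scatter. Among the compounds with values here, the change in compound 4 therefore has no close precedent, and the expectation in this assay is a step of modest size at most, with the direction uncertain; the estimate is a 1.5-fold lower number from compound 1 to compound 4 (0.18 log units; within the scatter).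

For compound 4 the expected value in this assay is 40000 nM, estimated to lie between 8000 nM and 150000 nM.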

Compound 4, concentration for 50% growth inhibition: 52300 nM
For compound 4 the middle estimate is 1.3-fold (0.12 log units) below the measured one; measured number inside the range.
By their numbers in this assay, from the lowest: compound 2; then compounds 4, 1 and 3 (each within the scatter of the next).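

In this assay, the first change shown on the amine nitrogen in the ring, phenyl in place of methyl, gives a 1.2-fold lower number from compound 1 to compound 4 (0.07 log units; within the scatter) and so stays within the scatter despite the added aromatic ring. The replacement of the whole group on the carbonyl carbon gives a 1.2-fold lower number from compound 3 to compound 4 (0.10 log units; within the scatter) and is also within the scatter, while a 12-fold higher number from compound 2 to compound 4 (1.10 log units; beyond the scatter) is large. Among these four compounds, compound 2 therefore stands alone with the lowest number in this assay, and compounds 1, 3 and 4 remain together, with no data here bearing on the reason for this split.

From the compounds shown here alone, whether an amine or a carboxylic acid on the phenyl of compound 4, or a longer chain in place of its phenyl, would move the number beyond the scatter remains open. The compounds shown also do not separate the contribution of the chlorine in the ((4-chlorophenyl)amino)amino group of compound 2 from that of the rest of the group.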